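The compounds below may be only part of what the source reports. "The series", "measured", "known", "first", "only" and "open" are said of these compounds alone.

Among the compounds with values here, compound 2, `O=C(CCCCCCc1ccccc1)c1nc(-c2cccnc2)co1`, gives 18 nM in an assay on isolated protein for inhibition of Fatty-acid amide hydrolase 1 (Rattus norvegicus) (on this read-out higher numbers stand for weaker inhibition and lower numbers for stronger inhibition), the lowest of the two numbers so far; compound 1, `O=C(CCCCCCc1ccccc1)c1nc(C(=O)C(F)(F)F)co1`, gives 470 nM. Within the data shown here, the only measured step, a 26-fold lower number from compound 1 to compound 2 (1.42 log units; beyond the scatter), bears on the change only loosely, since compound 3, `O=C(CCCCCCc1ccccc1)c1nc(C(F)(F)F)co1`, carries a trifluoromethyl in place of pyridin-3-yl on an aromatic carbon and thus loses the group that compound 2 gained there. Among the measured compounds shown here, no measured pair shows this exact swap. Compound 3 is therefore expected to give a higher number than compound 2, around a 33-fold higher number from compound 2 to compound 3 (1.52 log units; beyond the scatter), with the loss of the pyridin-3-yl not judged as large as the measured gain. The estimate for compound 3 in this assay is 600 nM, between 150 nM and 2500 nM.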

Compound 3, inhibition constant: 3.7 nM
Compound 3: middle estimate off by 160-fold (2.21 log units), on the high side; the whole stated range lies above it.
By their numbers in this assay, from the lowest: compound 3; then compound 2; then compound 1.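

At this aromatic carbon next to the ring nitrogen, a ring is not required for a low number in this assay: trifluoromethyl, with no ring, goes below pyridin-3-yl (a 4.9-fold lower number from compound 2 to compound 3 (0.69 log units; beyond the scatter)). Trifluoromethyl also stands far below (trifluoromethyl)carbonyl (a 130-fold lower number from compound 1 to compound 3 (2.10 log units; beyond the scatter)), so the order at this place runs trifluoromethyl, pyridin-3-yl, (trifluoromethyl)carbonyl from the lowest number. No supporting measurement accounts for this order. As far as these compounds go, whether a methyl, a lone fluorine, an amine or a carboxylic acid at this carbon would keep the number as low remains open. So does whether the order holds with a shorter chain than the one shared here.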